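This account rests on a few compounds, and the source may have more. Where it says the series, first, only, none or still open, it means among the compounds named here.

Values in a functional assay on MCF7 cells (Homo sapiens) for cytotoxicity, read by MTT assay, with a stated time of 72 h; on this read-out lower numbers stand for stronger inhibition and higher numbers for weaker inhibition:
- compound 1 `COc1ccc(/C=N/NC(=O)Nc2cc3c(Nc4ccc(F)c(Cl)c4)ncnc3cc2O[C@H]2CCOC2)cc1`: 27300 nM
- compound 2 `CCN(CC)c1ccc(/C=N/NC(=O)Nc2cc3c(Nc4ccc(F)c(Cl)c4)ncnc3cc2O[C@H]2CCOC2)c(O)c1`: 15600 nM
- compound 3 `COc1ccc(/C=N/NC(=O)Nc2cc3c(Nc4ccc(F)c(Cl)c4)ncnc3cc2OC)cc1`: 8140 nM

Compound 3 and compound 2 lie within the scatter of each other, and only compound 1 stands clear of compound 3: a 3.4-fold lower number from compound 1 to compound 3 (0.53 log units; beyond the scatter). Next comes compound 4 `CCN(CC)c1ccc(/C=N/NC(=O)Nc2cc3c(Nc4ccc(F)c(Cl)c4)ncnc3cc2OC)c(O)c1`, with this change: 4-(diethylamino)-2-hydroxyphenyl in place of 4-methoxyphenyl on a carbon with a double bond to nitrogen. The same exchange has one measured precedent, a 1.8-fold lower number from compound 1 to compound 2 (0.24 log units; within the scatter), which stays within the scatter. With a single precedent, no step beyond the scatter is expected in this assay, only a slight lean towards a lower number. The expected step is a 1.5-fold lower number from compound 3 to compound 4 (0.17 log units; within the scatter). Compound 4 is estimated at 5500 nM, with an expected range of 2200 nM to 13000 nM.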

Compound 4, half-maximal inhibitory concentration: 27300 nM
Compound 4: the middle estimate sits 5.0-fold (0.70 log units) below what was measured, outside the stated range (above it).
By their numbers in this assay, from the lowest: compounds 3, 2, 1 and 4 (each within the scatter of the next, the first and the last beyond it).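

With methyl on the aromatic oxygen, 4-(diethylamino)-2-hydroxyphenyl in place of 4-methoxyphenyl gives a 3.4-fold higher number from compound 3 to compound 4 (0.53 log units; beyond the scatter) in this assay, so this exchange does not carry over between the two cores: the same change on two cores in this assay, a 1.8-fold lower number (0.24 log units; within the scatter) from compound 1 to compound 2 and a 3.4-fold higher number (0.53 log units; beyond the scatter) from compound 3 to compound 4, 5.9-fold (0.77 log units) apart, beyond the scatter of two such steps. Methyl in place of oxolan-3-yl, with 4-(diethylamino)-2-hydroxyphenyl present, gives a 1.8-fold higher number from compound 2 to compound 4 (0.24 log units; within the scatter), which does not repeat the step seen with 4-methoxyphenyl: the same change on two cores in this assay, a 3.4-fold lower number (0.53 log units; beyond the scatter) from compound 1 to compound 3 and a 1.8-fold higher number (0.24 log units; within the scatter) from compound 2 to compound 4, 5.9-fold (0.77 log units) apart, beyond the scatter of two such steps. In these four compounds the two places therefore do not act independently.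

The diethylamino and hydroxyl groups remain inseparable here; 4-(diethylamino)phenyl and 2-hydroxyphenyl would each isolate one of them.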